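Amino Substitution on Two Related Cores: Cytotoxicity Compared

The source may report more compounds than this note shows. Statements on the series, on what has been measured and on what is new or still open speak of the compounds shown alone.

In a functional assay on A549 cells (Homo sapiens) for cytotoxicity, read by sulforhodamine B assay, with a stated time of 48 h (a higher number here means a weaker inhibitor of growth, a lower number a stronger inhibitor of growth), compound 1 `CCn1cc(-c2nc3ccccc3[nH]2)c(=O)c2cc(F)c(N3CCNCC3)cc21` gives 600 nM. In this assay compound 2 `CCn1cc(-c2nc3ccccc3[nH]2)c(=O)c2cc(F)c(N3CCNCC3)nc21` gives 4900 nM. Compound 3 `CCn1cc(-c2nc3ccc(N)cc3[nH]2)c(=O)c2cc(F)c(N3CCNCC3)cc21` gives only a limit of the assay, > 10000 nM.

Compound 1 and compound 2 carry the same side groups, but the difference between their two cores is not broken down here; compound 2 stands at the higher number, beyond the scatter. Adding an amino group to compound 1, (amino in place of hydrogen on an aromatic carbon), gives an at least 16-fold higher number from compound 1 to compound 3 (1.22 log units; beyond the scatter), and compound 3 sits at the limit of > 10000 nM in this assay, at which 1 of the 3 values shown sits.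

Compound 4 `CCn1cc(-c2nc3ccc(N)cc3[nH]2)c(=O)c2cc(F)c(N3CCNCC3)nc21` is the same change made on compound 2: amino in place of hydrogen on an aromatic carbon. The place is described in the same words as for compound 3. Because compound 2 already gives 4900 nM, a step like an at least 16-fold higher number from compound 1 to compound 3 (1.22 log units; beyond the scatter) is expected to carry compound 4 past the limit. Compound 4 is therefore expected to give around 60000 nM, within 15000 nM to 300000 nM, an estimated step of a 12-fold higher number from compound 2 to compound 4 (1.09 log units; beyond the scatter).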

Compound 4, concentration for 50% growth inhibition: 500 nM
The estimate for compound 4 lay 120-fold (2.08 log units) above the measured number; the whole stated range lies above it.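

On the core of compound 2, amino in place of hydrogen on an aromatic carbon gives a 9.8-fold lower number from compound 2 to compound 4 (0.99 log units; beyond the scatter) in this assay. The same change therefore runs in opposite directions on the two cores: the same change on two cores in this assay, an at least 16-fold higher number (1.22 log units; beyond the scatter) from compound 1 to compound 3 and a 9.8-fold lower number (0.99 log units; beyond the scatter) from compound 2 to compound 4, at least 160-fold (2.21 log units) apart, beyond the scatter of two such steps. This shows that the effect of this change on one core cannot be carried over to the other in this series, but with a single pair on each core it does not show why the two cores differ.

On these data alone, compound 3 gives > 10000 nM, which is a limit of the assay, so the true size of its step stays open. Also open, as far as these compounds go, is whether a hydroxyl or a methoxy group in that same place would separate the two cores in the same way.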